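A few compounds are considered here, and "the series" means these few. Any claim that something is new, unique, unknown or untested is made for them only; others in the source may bear on it.

Compounds measured so far:
- compound 1, `COc1cccc(C(=O)Nc2cccc(-c3oc4cc(-c5ccc(F)cc5)ccc4c(=O)c3O)c2)c1`: 10800 nM
- compound 2, `O=C(Nc1cccc(-c2oc3cc(-c4ccc(F)cc4)ccc3c(=O)c2O)c1)c1cc(F)cc(F)c1`: 7620 nM

Notes on the series. Both measured compounds share a core that carries a (4-fluorophenyl) group and an amide-linked aryl ring; they differ only in the aryl group on the carbonyl carbon. In a functional assay on A549 cells (Homo sapiens) for antiproliferative activity, read by CCK-8 assay, with a stated time of 72 h (a lower number here means a stronger inhibitor, a higher number a weaker inhibitor), compound 1 gives 10800 nM and compound 2 gives 7620 nM. Among the measured compounds shown here, the single measured step, a 1.4-fold lower number from compound 1 to compound 2 (0.15 log units; within the scatter), does not separate the two compounds. Compound 2 has the lower of the two numbers, but the gap to compound 1 is within the scatter, so no order can be read from it.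

Compound 3, `O=C(Nc1cccc(-c2oc3cc(-c4ccc(F)cc4)ccc3c(=O)c2O)c1)c1cnc(Cl)nc1Cl`, is not yet measured. It differs from compound 2 as follows: 2,4-dichloropyrimidin-5-yl in place of 3,5-difluorophenyl on a carbonyl carbon. For the measured compounds named here, the only step that bears on this position is the exchange of one aryl group for another from compound 1 to compound 2, which stayed within the scatter. Going by the values given here, no measured step involves a heteroaryl group or chlorine on this carbonyl carbon, so there is no direct precedent. With that limited evidence the expected step is small: a 1.0-fold higher number from compound 2 to compound 3 (0.02 log units; within the scatter), in either direction, none beyond the scatter with confidence. Compound 3 is therefore estimated at 8000 nM, with a range from 3000 nM to 25000 nM.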

Compound 3, half-maximal inhibitory concentration: > 100000 nM
Compound 3: a limit, no number (the forecaster's own chance of this, stated with the estimate: 15%); middle value at least 12-fold (1.09 log units) from the limit.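

In this assay compound 3 gives > 100000 nM, which is a limit of the assay and not a number. The aryl position on the carbonyl carbon therefore does not accept every exchange: 2,4-dichloropyrimidin-5-yl in place of 3,5-difluorophenyl gives an at least 13-fold higher number from compound 2 to compound 3 (1.11 log units; beyond the scatter), and in place of 3-methoxyphenyl it gives an at least 9.2-fold higher number from compound 1 to compound 3 (0.96 log units; beyond the scatter). Both steps are lower bounds set by a single limit, so their direction is clear but their true size is not fixed: the limit of > 100000 nM in this assay, at which 1 of the 3 values shown sits.

The change brings in the ring nitrogens and the two chlorine atoms together, so the compounds shown do not separate the contribution of the pyrimidine ring from that of the chlorines, and no cause for the loss of activity can be read from these values. As far as these compounds go, it remains open whether an unsubstituted pyrimidin-5-yl, a 2,4-dichlorophenyl or a pyrimidine carrying an amine in place of chlorine on the same carbonyl carbon would return to the range of compound 1 and compound 2.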